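Series notes: second chloro on the terminal ring

A few compounds are considered here, and "the series" means these few. Any claim that something is new, unique, unknown or untested is made for them only; others in the source may bear on it.

Compound 1 `Cc1ccc(C(=O)c2ccc(C(=O)c3ccc(C(=O)O)cc3)cc2)cc1`, compound 2 `O=C(O)c1ccc(C(=O)c2ccc(C(=O)c3ccc(C(=O)O)cc3)cc2)cc1` and compound 3 `O=C(O)c1ccc(C(=O)c2ccc(C(=O)c3ccc(Cl)cc3)cc2)cc1` share one core. In an assay on CHO cells for inhibition of 3-oxo-5-alpha-steroid 4-dehydrogenase 2 (Homo sapiens) (a higher number here means a weaker inhibitor, a lower number a stronger inhibitor), compound 1 gives 10 nM, compound 2 gives 1000 nM and compound 3 gives 35 nM; compound 3 thus stands second highest of the three, with a 3.5-fold higher number from compound 1 to compound 3 (0.54 log units; beyond the scatter) and a 29-fold lower number from compound 2 to compound 3 (1.46 log units; beyond the scatter). Compound 4 is `O=C(O)c1ccc(C(=O)c2ccc(C(=O)c3ccc(Cl)cc3Cl)cc2)cc1`, and the change from compound 3 is chloro in place of hydrogen on an aromatic carbon, placed ortho to a large group and meta to a chloro group. Among the compounds with values here, no measured step adds a substituent to an already substituted ring; the steps at hand swap one group for another, so a step within the scatter is expected in this assay. The estimate for compound 4 is 35 nM, range 10 nM to 120 nM, meaning no change at the digits printed from compound 3 to compound 4 (within the scatter).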

Compound 4, inhibition constant: 35 nM
Estimate against measurement, compound 4: no gap at the digits printed, within the range that was stated.
By their numbers in this assay, from the lowest: compound 1; then compounds 3 and 4 (each within the scatter of the next); then compound 2.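

In this assay, within the data shown here, the position ortho to a large group and meta to a chloro group accepts an added chloro with no change at the digits printed from compound 3 to compound 4 (within the scatter), and unlike the earlier steps, this one adds a group to an already substituted ring rather than swapping one group for another. The 2,4-dichlorophenyl group shows a 29-fold lower number from compound 2 to compound 4 (1.46 log units; beyond the scatter) and a 3.5-fold higher number from compound 1 to compound 4 (0.54 log units; beyond the scatter), the same sizes as those seen for the 4-chlorophenyl group. No measured evidence bears on this result. Still open, on these data alone, is whether a methoxy group or an amine at this position would also leave the number unchanged, and whether an added chloro would do the same on the 4-methylphenyl ring of compound 1.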